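One Aryl Swap at the Amide-Type Nitrogen

The compounds below may be only part of what the source reports. "The series", "measured", "known", "first", "only" and "open" are said of these compounds alone.

Compound 1 `O=C(Nc1ccc(F)cc1)N[C@H]1CC[C@H](Oc2ccc(F)cc2)CC1`: 20000 nM
Compound 2 `O=C(Nc1ccccc1[N+](=O)[O-])N[C@H]1CC[C@H](Oc2ccc(F)cc2)CC1`: 3500 nM
Compound 3 `O=C(Nc1cccc(Cl)c1)N[C@H]1CC[C@H](Oc2ccc(F)cc2)CC1`: 5900 nM

These three compounds were tested in a functional assay on CRL2813 cells (Homo sapiens) for cytotoxicity, read by sulforhodamine B assay, with a stated time of 5 days; a lower number here means a stronger inhibitor, a higher number a weaker inhibitor. Compound 1 gives the highest number of the three and is thus the weakest of them; compound 3 sits nearer to it and compound 2 further away. The not yet measured compound 4 `O=C(Nc1ccccc1I)N[C@H]1CC[C@H](Oc2ccc(F)cc2)CC1` differs from compound 1 only in the group on the amide-type nitrogen: 2-iodophenyl in place of 4-fluorophenyl on an amide-type nitrogen.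

Two measured steps start from compound 1 and change this same group. One step is a 5.7-fold lower number from compound 1 to compound 2 (0.76 log units; beyond the scatter), the other is a 3.4-fold lower number from compound 1 to compound 3 (0.53 log units; beyond the scatter); both are modest gains that reach beyond the scatter. The step of a 1.7-fold higher number from compound 2 to compound 3 (0.23 log units; within the scatter) stays within the scatter, so the two substituted compounds cannot be ordered. The change to compound 4 is of the same kind as these, so a modest downward step in this assay is expected, a 4.0-fold lower number from compound 1 to compound 4 (0.60 log units; beyond the scatter). Compound 4 is therefore estimated at 5000 nM in this assay, with a range from 2000 nM to 15000 nM.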

Compound 4, half-maximal inhibitory concentration: > 20000 nM
Compound 4 was reported as a limit; the forecaster's own chance of this, stated with the estimate: 5%; at least 4.0-fold (0.60 log units) between middle value and limit.
By their numbers in this assay, from the lowest: compounds 2 and 3 (each within the scatter of the next); then compound 1.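

In this assay compound 4 gives > 20000 nM as a limit, not as a number. Changes to this group therefore do not all go the same way: an at least 3.3-fold higher number from compound 3 to compound 4 (0.53 log units; beyond the scatter) and an at least 5.7-fold higher number from compound 2 to compound 4 (0.75 log units; beyond the scatter) show that 2-iodophenyl does not share the lower numbers of the other two groups, and the second of these steps swaps only nitro for iodo on an aromatic carbon. The remaining step is a number no lower from compound 1 to compound 4 (the limit leaves the size open) and cannot be read, because the limit leaves its size open: the limit of > 20000 nM in this assay, at which 1 of the 4 values shown sits.

The compounds shown leave open whether an amine or a carboxylic acid in place of that iodo would behave like compound 2 or like compound 4. They also leave open what a longer chain in place of the aryl group on the amide-type nitrogen would do.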